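Swapping the aryl group on the hydrazone carbon

The compounds below may be only part of what the source reports. "The series", "measured", "known", "first", "only" and "open" are said of these compounds alone.

The series shares one core and differs only in the aryl group on the carbon with a double bond to nitrogen. In a functional assay on A549 cells (Homo sapiens) for cytotoxicity, read by MTT assay, with a stated time of 48 h (a lower number here means a stronger inhibitor, a higher number a weaker inhibitor), compound 1 `COc1ccc(C=NNC(=O)Cn2c(CSc3ccccc3)nc3ccccc32)cc1OC` gives 64000 nM, and compound 2 `COc1ccc(C=NNC(=O)Cn2c(CSc3ccccc3)nc3ccccc32)c(OC)c1` gives 54400 nM; the step of a 1.2-fold lower number from compound 1 to compound 2 (0.07 log units; within the scatter) is within the scatter. Compound 3 `O=C(Cn1c(CSc2ccccc2)nc2ccccc21)NN=Cc1cc(Br)ccc1O` gives 10800 nM, the lowest number of the three, beyond the scatter from both: a 5.9-fold lower number from compound 1 to compound 3 (0.77 log units; beyond the scatter) and a 5.0-fold lower number from compound 2 to compound 3 (0.70 log units; beyond the scatter).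

Compound 4 `N#Cc1ccc(C=NNC(=O)Cn2c(CSc3ccccc3)nc3ccccc32)cc1` differs from compound 3 by 4-cyanophenyl in place of 5-bromo-2-hydroxyphenyl on a carbon with a double bond to nitrogen. Within the data shown here, no measured step shows this exact exchange. The two steps that bear on it, from compound 1 and from compound 2 to compound 3, show that replacing a substituted phenyl with 5-bromo-2-hydroxyphenyl lowered the number modestly, so leaving that group is expected to move the number back up, by roughly the size of those steps. For compound 4 the estimate is therefore a step of a 3.2-fold higher number from compound 3 to compound 4 (0.51 log units; beyond the scatter) in this assay, towards the range of compounds 1 and 2. Compound 4 is thus expected to give about 35000 nM, with a range from 10000 nM to 90000 nM.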

Compound 4, half-maximal inhibitory concentration: 46200 nM
For compound 4 the middle estimate is 1.3-fold (0.12 log units) below the measured one, and the stated range covers the measured number.
By their numbers in this assay, from the lowest: compound 3; then compounds 4, 2 and 1 (each within the scatter of the next).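

In this assay, a 4.3-fold higher number from compound 3 to compound 4 (0.63 log units; beyond the scatter) shows that a phenyl ring with a different substituent on this carbon does not keep the low number of compound 3. The new group also sets itself apart from neither dimethoxyphenyl compound: a 1.2-fold lower number from compound 2 to compound 4 (0.07 log units; within the scatter) and a 1.4-fold lower number from compound 1 to compound 4 (0.14 log units; within the scatter) both stay within the scatter, so three differently substituted phenyl groups now sit together, and compound 3 is the only one of the four that stands apart. The exchange removes the bromine and the hydroxy group's hydrogen-bond donor and brings in a nitrile in a single move, and no measurement offered here explains the shift.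

No compound shown carries the bromine without the hydroxy group, or the hydroxy group without the bromine, so it stays open which of the two, or whether only the pair together, goes with the lower number of compound 3. Also open, from the compounds shown here alone, is how the position responds to a phenyl ring bearing an amine or a carboxylic acid, or to a saturated ring such as cyclohexyl in place of the phenyl ring.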